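This account rests on a few compounds, and the source may have more. Where it says the series, first, only, none or still open, it means among the compounds named here.

Of the compounds shown here, three sharing one core have been measured in a functional assay on NCI-H520 cells (Homo sapiens) for inhibition, read by MTT assay, with a stated time of 48 h, tested at 10 uM; a higher number here means more inhibition at the concentration tested (going by the name of the read-out), a lower number less inhibition. Compound 1 `COc1ccc(Br)cc1Nc1cc(NC(=O)Nc2c(Cl)cccc2Cl)ncn1` gives 45% in this assay. Compound 2 `COc1cc(NC(=O)Nc2cc(Nc3cc(Br)ccc3OC)ncn2)cc(OC)c1` gives 43.5%, and compound 3 `O=C(Nc1cc(Nc2ccc(F)c(Cl)c2)ncn1)Nc1c(Cl)cccc1Cl` gives 39.5%. Among these three numbers compound 2 stands second highest, nearest to compound 1 and furthest from compound 3, with both gaps within the scatter. The two measured steps are both small: a number 1.5 percentage points lower from compound 1 to compound 2 (within the scatter), and a number 5.5 percentage points lower from compound 1 to compound 3 (within the scatter).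

Compound 4 `COc1cc(NC(=O)Nc2cc(Nc3cc(I)ccc3OC)ncn2)cc(OC)c1` differs from compound 2 by iodo in place of bromo on an aromatic carbon. The step from compound 1 to compound 3 bears on it most, since it also exchanges the 5-bromo-2-methoxyphenyl group on the nitrogen on an aromatic ring, and it stayed within the scatter; the step from compound 1 to compound 2, which alters the group on the amide-type nitrogen, likewise stayed within the scatter. Among the measured compounds shown here, neither is the bromo-to-iodo exchange itself, so no direct precedent exists. Because a number 5.5 percentage points lower from compound 1 to compound 3 (within the scatter) did not move the number beyond the scatter even with a larger change on that ring, the expectation is a step of a number 0.5 percentage points higher from compound 2 to compound 4 (within the scatter), nothing beyond the scatter. The value of compound 4 is therefore estimated at 44%, with a range from 32% to 56%.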

Compound 4, a percentage reported as inhibition, at one concentration (the size of the read-out at that concentration, not a potency): 55%
Estimate against measurement, compound 4: 11 percentage points below; the measured number falls inside the stated range.
By their numbers in this assay, from the lowest: compounds 3, 2, 1 and 4 (each within the scatter of the next, the first and the last beyond it).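

In this assay the exchange of bromo for iodo on the aromatic carbon para to a methoxy group gives a number 11.5 percentage points higher from compound 2 to compound 4 (beyond the scatter) and is the only step shown to pass beyond the scatter. Among the compounds shown here, the change replaces one heavy atom with one heavy atom, adds no ring, leaves the counts of hydrogen-bond donors and acceptors at zero on both sides, and brings no net charge, yet the replacement of the whole 5-bromo-2-methoxyphenyl group gave only a number 5.5 percentage points lower from compound 1 to compound 3 (within the scatter) in the same assay, so this position responds to the identity of a single halogen in a way the earlier steps gave no sign of. Nothing measured among these compounds accounts for the step.

From the compounds shown here alone, whether iodo in place of bromo gives a similar step with 2,6-dichlorophenyl on the amide-type nitrogen, as in compound 1, remains open. Also open, going by these compounds, is what a methyl, a trifluoromethyl or an ethynyl group would give on this same aromatic carbon, and whether the step would hold at concentrations other than the single one tested here.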